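Swapping a Piperidine for an Ethylpiperazine Tail

A few compounds are considered here, and "the series" means these few. Any claim that something is new, unique, unknown or untested is made for them only; others in the source may bear on it.

Of the compounds shown here, three share a core and have been tested in a functional assay on CCRF-CEM cells for antagonist activity at C-X-C chemokine receptor type 4 (Homo sapiens), read by calcium flux, with stated times of 25 min and 90 s; a lower number here means a stronger inhibitor, a higher number a weaker inhibitor. Compound 1 `c1ccc2c(c1)CN[C@@H](CN(CC[C@H]1CCCNC1)[C@H]1CCCc3cccnc31)C2` gives 16 nM in this assay, the lowest of the three numbers. Compound 3 `c1cnc2c(c1)CCC[C@@H]2N(CCCN1CCNCC1)Cc1nc2ccccc2[nH]1` gives 45 nM in this assay, and compound 2 `c1ccc2c(c1)CN[C@H](CN(CCCN1CCNCC1)[C@H]1CCCc3cccnc31)C2` gives 1150 nM in this assay. For the measured compounds named here, the only single-point comparison available is a 26-fold lower number from compound 2 to compound 3 (1.41 log units; beyond the scatter), a change at a different part of the molecule from the one considered here. Going by the values given here, compound 2 and compound 1 differ in more than one place, so their two values show only that the piperazine-bearing compound 2 sits far weaker.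

Compound 4 `CCN1CCN(CCCN(C[C@H]2Cc3ccccc3CN2)[C@H]2CCCc3cccnc32)CC1` is not yet measured. It differs from compound 1 by (4-ethylpiperazin-1-yl)methyl in place of piperidin-3-yl on a saturated chain carbon, two bonds along the chain from an amine nitrogen.

Among the compounds with values here, no measured step reports this exact change. The gap between compound 1 and compound 2 hints that a piperazine tail can cost potency, but that pair carries a second difference, so it is weak guidance. The change is therefore expected to weaken the compound moderately, with wide uncertainty: the estimated step is a 5.0-fold higher number from compound 1 to compound 4 (0.70 log units; beyond the scatter). Compound 4 is expected to give about 80 nM in this assay, within a range from 15 nM to 500 nM.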

Compound 4, half-maximal inhibitory concentration: 33 nM
Compound 4: the middle estimate sits 2.4-fold (0.38 log units) above what was measured, and the stated range covers the measured number.
By their numbers in this assay, from the lowest: compound 1; then compounds 4 and 3 (each within the scatter of the next); then compound 2.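

In this assay, the swap of piperidin-3-yl for (4-ethylpiperazin-1-yl)methyl gives a 2.1-fold higher number from compound 1 to compound 4 (0.31 log units; beyond the scatter), a modest step that lies only just beyond the usual scatter, even though the entering group is clearly larger, with 9 heavy atoms against 6, a second ring nitrogen and no hydrogen-bond donor. This position therefore accepts a piperazine-bearing tail, and compound 4 still gives 33 nM, so the hydrogen-bond donor of the piperidine ring is not needed for a number in this range, and a piperazine ring in the tail does not by itself bring a large loss. Nothing measured here gives a reason for the size of this step.

The step changes the ring, the chain leading to it and the ethyl group all at once, so the compounds shown cannot assign the shift to any one of these parts. Also open, from the compounds shown here alone, is how this position would respond to a 4-methylpiperazin-1-yl or morpholin-4-yl group on the same chain, or to a simple primary amine at the end of a longer chain.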